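Benzyl amide in place of chlorophenyl amide: tolerability outlook

This account rests on a few compounds, and the source may have more. Where it says the series, first, only, none or still open, it means among the compounds named here.

Measured compounds:
Compound 1, `O=C(CSc1nnc(-c2ccncc2)s1)Nc1ccc(Cl)cc1`, gives > 50000 nM in an ADME assay on BHK-21 cells (Mesocricetus auratus) for cytotoxicity, with a stated time of 3 days (a lower number here means that less compound is tolerated, a higher number that more compound is tolerated), which is a limit of the assay and not a number.
Compound 2, `CC(CSc1nnc(-c2ccncc2)s1)C(=O)Nc1ccccc1Cl`, gives > 50000 nM in this assay, again a limit.
Compound 3, `CC(Sc1nnc(-c2ccncc2)s1)C(=O)Nc1ccc(Cl)cc1`, gives > 50000 nM in this assay, again a limit.

Compound 1 therefore stands at a limit, and the other two values shown stand at the same limit, so all three sit at the limit of > 50000 nM in this assay, at which 3 of the 3 values shown sit. For the measured compounds named here, only one measured pair differs in a single place, and that step, a step that the two limits leave unreadable from compound 1 to compound 3, cannot be read because both of its ends rest at the limit of > 50000 nM in this assay, at which 3 of the 3 values shown sit.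

The compound not yet measured is compound 4, `O=C(CSc1nnc(-c2ccncc2)s1)NCc1ccccc1`. It differs from compound 1 by benzyl in place of 4-chlorophenyl on an amide-type nitrogen. Going by the values given here, no measured step covers this kind of change, and the one measured step gives no size at all. Nothing here points to a direction beyond the scatter, so the expected step is a number no higher from compound 1 to compound 4 (the limit leaves the size open). Compound 4 is thus expected to give 50000 nM, within 20000 nM to 100000 nM, most likely again as a limit.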

Compound 4, half-maximal cytotoxic concentration: 11300 nM
For compound 4 the middle estimate is 4.4-fold (0.65 log units) above the measured one; measured number outside the range, below it.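

On the amide-type nitrogen, benzyl in place of 4-chlorophenyl gives an at least 4.4-fold lower number from compound 1 to compound 4 (0.64 log units; beyond the scatter) in this assay, so a change at this position can shift how much compound the cells tolerate. For the compounds shown here, the earlier compounds could not show this, as the one earlier step cannot be read, and here the shift appears even though both groups hold one six-membered aromatic ring of carbon only. Going by these compounds, the full size of the step stays open because compound 1 rests at a limit and not at a number: the limit of > 50000 nM in this assay, at which 3 of the 4 values shown sit.

Benzyl differs from 4-chlorophenyl both by lacking the chlorine and by holding an extra carbon, so a plain phenyl or a 4-chlorobenzyl on the same nitrogen would be needed to separate the two. On these data alone, whether a longer chain such as phenethyl would give a lower or a higher number also stays open.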